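Chloro for Methyl on the Benzimidazole of Compound 2

The source may hold more compounds than are shown below. What is called first, only, known or untested is meant among the compounds shown, and "the series" means these compounds.

Measured compounds:
compound 1, `Cc1ccc2nc([C@H](CC3CCN(CC(C)C)CC3)N3C(=O)CN(c4ccc(Oc5ccccc5)cc4)C3=O)n(C)c2c1`, 16400 nM
compound 2, `CC(=O)N1CCC(C[C@@H](c2nc3ccc(C)cc3n2C)N2C(=O)CN(c3ccc(Oc4ccccc4)cc3)C2=O)CC1`, 1300 nM
compound 3, `Cc1ccc2nc([C@H](CC3CCN(C(=O)C(C)C)CC3)N3C(=O)CN(c4ccc(Oc5ccccc5)cc4)C3=O)n(C)c2c1`, 35 nM

The three measured compounds share one core and differ only at the amine nitrogen in a ring. In an assay on isolated protein for antagonist activity at Bile acid receptor (Homo sapiens), read by TR-FRET and LanthaScreen (on this read-out higher numbers stand for weaker inhibition and lower numbers for stronger inhibition), compound 2 gives 1300 nM, the second highest of the three numbers. Its nearest neighbour is compound 1, with a 13-fold lower number from compound 1 to compound 2 (1.10 log units; beyond the scatter); the furthest is compound 3, with a 37-fold lower number from compound 2 to compound 3 (1.57 log units; beyond the scatter). The full span of the set, a 470-fold lower number from compound 1 to compound 3 (2.67 log units; beyond the scatter), also belongs to the piperidine nitrogen substituent.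

Compound 4, `CC(=O)N1CCC(C[C@@H](c2nc3ccc(Cl)cc3n2C)N2C(=O)CN(c3ccc(Oc4ccccc4)cc3)C2=O)CC1`, is not yet measured. It changes compound 2 at a different place: chloro in place of methyl on an aromatic carbon. The change sits on an aromatic carbon of a six-membered aromatic ring of carbon only, part of a fused or bridged system of two rings; the group that leaves and the group that enters each count one heavy atom, with no donors, acceptors or charge.

Going by the values given here, none of the measured steps touches this ring; all three concern the acetyl, isobutyl or isopropylcarbonyl group on the ring nitrogen. Among the compounds with values here, with no step bearing directly on the exchange, the expectation for compound 4 is a step of no change at the digits printed from compound 2 to compound 4 (within the scatter), that is, no step beyond the usual scatter in either direction. Compound 4 is therefore estimated at 1300 nM, within 450 nM to 3800 nM.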

Compound 4, half-maximal inhibitory concentration: 3500 nM
Estimate against measurement, compound 4: 2.7-fold (0.43 log units) below; the range from low to high includes it.
By their numbers in this assay, from the lowest: compound 3; then compound 2; then compound 4; then compound 1.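

The result shows that this aromatic carbon is not indifferent to a like-sized exchange: although one heavy atom leaves, one enters and neither brings donors, acceptors or charge, chloro in place of methyl gives a 2.7-fold higher number from compound 2 to compound 4 (0.43 log units; beyond the scatter) in this assay and so goes with weaker inhibition. This is the first measured step outside the substituent on the ring nitrogen, and it is modest beside a 37-fold lower number from compound 2 to compound 3 (1.57 log units; beyond the scatter) and a 13-fold lower number from compound 1 to compound 2 (1.10 log units; beyond the scatter) among these compounds, so the largest steps shown still belong to that nitrogen substituent. Nothing in the data shown accounts for the direction or the size of the new step.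

On these data alone, whether the chloro exchange would carry a step of similar size alongside the isopropylcarbonyl group of compound 3 stays open, as chloro appears here only with the acetyl group of compound 4. The compounds shown also leave open how this aromatic carbon would respond to a hydrogen, a fluoro group, a methoxy group or a nitrile, and with only methyl and chloro in hand, no trend at this position can be drawn.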